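Chromene chalcones against colon carcinoma cells: nitro to chlorohydroxy

The compounds below may be only part of what the source reports. "The series", "measured", "known", "first", "only" and "open" are said of these compounds alone.

Measured compounds:
compound 1 `COc1ccc(C(=O)/C=C/c2ccc3ccccc3c2)c2c1C=CC(C)(C)O2` — 4480 nM
compound 2 `COc1ccc(C(=O)/C=C/c2cccc([N+](=O)[O-])c2)c2c1C=CC(C)(C)O2` — 4260 nM
compound 3 `COc1ccc(C(=O)/C=C/c2ccc(C(F)(F)F)cc2)c2c1C=CC(C)(C)O2` — > 10000 nM

Three chalcones on a shared core have been tested in a functional assay on HT-29 cells (Homo sapiens) for antiproliferative activity, read by MTT assay, with a stated time of 24 h; on this read-out lower numbers stand for stronger inhibition and higher numbers for weaker inhibition. Compound 2 gives 4260 nM and stands lowest of the two numbers; its nearest neighbour is compound 1 with 4480 nM, a gap within the scatter, so no order between the two can be claimed. For compound 3 the assay reports only a limit, > 10000 nM, and not a number; this is the one case at the limit of > 10000 nM in this assay, at which 1 of the 3 values shown sits.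

Compound 4 `COc1ccc(C(=O)/C=C/c2cc(Cl)ccc2O)c2c1C=CC(C)(C)O2` is not yet measured. It differs from compound 2 in one place:
5-chloro-2-hydroxyphenyl in place of 3-nitrophenyl on a double-bonded chain carbon bound to a double-bonded chain carbon

Among the compounds with values here, no step between measured compounds is available, so there is no measured guide to the size of the change. Two measured neighbours sit within the scatter of each other and one is a limit; on this basis a step of no more than modest size is expected in this assay, in either direction, most likely none beyond the scatter. Compound 4 is expected to give 5500 nM, with a range from 2000 nM to 15000 nM. The step from compound 2 that this estimate means is a 1.3-fold higher number from compound 2 to compound 4 (0.11 log units; within the scatter), a small weakening at most.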

Compound 4, half-maximal inhibitory concentration: 4970 nM
For compound 4 the middle estimate is 1.1-fold (0.04 log units) above the measured one, within the range that was stated.
By their numbers in this assay, from the lowest: compounds 2, 1 and 4 (each within the scatter of the next). At a limit, above all of these: compound 3.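

In this assay, placing 5-chloro-2-hydroxyphenyl in place of 3-nitrophenyl on a double-bonded chain carbon bound to a double-bonded chain carbon gives a 1.2-fold higher number from compound 2 to compound 4 (0.07 log units; within the scatter). Within the data shown here, this is the first step that can be read, and it shows that this position accepts a substantial exchange with no difference beyond the scatter: the entering group has 1 hydrogen-bond donor where the leaving group has 0, and it brings chlorine and carries no nitrogen. For this pair, the nitro group is therefore not needed to keep the number within the scatter of compound 2, although the two groups share little beyond the six-membered aromatic ring of carbon only.

Compound 3 remains a limit and not a number, so steps to it cannot be read: the limit of > 10000 nM in this assay, at which 1 of the 4 values shown sits. Still open, going by these compounds, is what the chlorine and the hydroxyl of compound 4 each contribute alone, and whether an amine or a carboxylic acid on the aromatic ring at this place would give a step beyond the scatter.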